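Trimming the Amine on the Side Chain of Compound 3

The source may hold more compounds than are shown below. What is called first, only, known or untested is meant among the compounds shown, and "the series" means these compounds.

Compound 1, `CC(C)C[C@H](N)c1cc(C(F)(F)F)ccc1N1CCN(C(=O)C2C(=O)OCC2c2ccc(Cl)cc2)CC1`, gives 260 nM in an assay on HEK293 cells for displacement of a labelled ligand from Melanocortin receptor 4 (Homo sapiens); a higher number here means a weaker inhibitor, a lower number a stronger inhibitor.
Compound 2, `CC(C)C[C@H](NC(=O)CCN(C)C)c1cc(C(F)(F)F)ccc1N1CCN(C(=O)[C@H]2C[S+]([O-])C[C@@H]2c2ccc(Cl)cc2)CC1`, gives 230 nM in this assay.
Compound 3, `CC(C)C[C@H](NC(=O)CCN(C)C)c1cc(C(F)(F)F)ccc1N1CCN(C(=O)C2C(=O)OCC2c2ccc(Cl)cc2)CC1`, gives 290 nM in this assay.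

Compound 3 carries the highest of these three numbers, but its nearest neighbour is compound 1, and the two lie within the scatter of each other; compound 2, which differs from compound 3 in the ring attached to the carbonyl, also lies within the scatter of compound 3, so the three compounds are indistinguishable on these numbers.

Compound 4, `CC(C)C[C@H](NC(=O)CCN)c1cc(C(F)(F)F)ccc1N1CCN(C(=O)C2C(=O)OCC2c2ccc(Cl)cc2)CC1`, has not yet been measured. It differs from compound 3 in one place: amino in place of dimethylamino on a saturated chain carbon, two bonds along the chain from a carbonyl carbon. Among the measured compounds shown here, the one measured step that bears on this region is a 1.1-fold higher number from compound 1 to compound 3 (0.05 log units; within the scatter), which shows that attaching the whole side chain to the amine nitrogen left this assay unchanged. Removing two methyl groups from the end of that same chain is therefore expected to give a step of no change at the digits printed from compound 3 to compound 4 (within the scatter), no change beyond the scatter. Compound 4 is estimated at 290 nM, with a range from 120 nM to 700 nM.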

Compound 4, inhibition constant: 180 nM
Compound 4: the middle estimate sits 1.6-fold (0.21 log units) above what was measured; the measured number falls inside the stated range.
By their numbers in this assay, from the lowest: compounds 4, 2, 1 and 3 (each within the scatter of the next).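

In this assay the end of the side chain now has a measured step of its own: a 1.6-fold lower number from compound 3 to compound 4 (0.21 log units; within the scatter) stays within the scatter, so amino and dimethylamino cannot be told apart at this place, on a saturated chain carbon, two bonds along the chain from a carbonyl carbon. The whole (2-aminoethyl)carbonyl group on the amine nitrogen reads the same way, as a 1.4-fold lower number from compound 1 to compound 4 (0.16 log units; within the scatter) is also within the scatter, so neither form of the chain separates from the unsubstituted amine of compound 1. No measurement shown offers an explanation for these readings.

As far as these compounds go, whether a carboxylic acid or a longer chain carrying the amino group would give a step beyond the scatter remains open. Also open, from the compounds shown here alone, is whether amino in place of dimethylamino reads the same with the ring attached to the carbonyl in compound 2.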